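The source may hold more compounds than are shown below. What is called first, only, known or untested is meant among the compounds shown, and "the series" means these compounds.

Measured so far in an ADME assay on microsomes from liver (Homo sapiens) for metabolic stability, read by LC-MS, with a stated time of 10 min, tested at 0.5 uM; on this read-out higher numbers stand for a more stable compound and lower numbers for a less stable compound:
- compound 1 (`c1ccc2c(c1)CN[C@@H](CN(CC1CCNCC1)[C@H]1CCCc3cccnc31)C2`) gives 86%
- compound 2 (`c1ccc2c(c1)CN[C@@H](CN(CC[C@@H]1CCCNC1)[C@H]1CCCc3cccnc31)C2`) gives 75%
- compound 3 (`CCN1CCN(CCCN(C[C@H]2Cc3ccccc3CN2)[C@H]2CCCc3cccnc32)CC1`) gives 59%

Compound 3 stands lowest of the three. Compound 4 (`c1ccc2c(c1)CN[C@@H](CN(CC[C@H]1CCCNC1)[C@H]1CCCc3cccnc31)C2`) differs from it by one change, (piperidin-3-yl in place of (4-ethylpiperazin-1-yl)methyl on a saturated chain carbon, two bonds along the chain from an amine nitrogen), with piperidin-3-yl in place of (4-ethylpiperazin-1-yl)methyl on a saturated chain carbon, two bonds along the chain from an amine nitrogen. Compound 2 also carries piperidin-3-yl. The closest evidence is therefore a number 16 percentage points lower from compound 2 to compound 3 (beyond the scatter), which is this change run backwards, while a number 27 percentage points lower from compound 1 to compound 3 (beyond the scatter) also ends at a lower number. Both steps are modest but beyond the scatter, so a modest rise is expected, an estimated a number 16 percentage points higher from compound 3 to compound 4 (beyond the scatter). For compound 4 the expected value is 75%, with an estimated range from 63% to 87%.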

Compound 4, percent of the compound remaining: 93%
The estimate for compound 4 lay 18 percentage points below the measured number, and the stated range ends below it.
By their numbers in this assay, from the lowest: compound 3; then compound 2; then compounds 1 and 4 (each within the scatter of the next).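

With the ring carbon drawn R, replacing (4-ethylpiperazin-1-yl)methyl with piperidin-3-yl gives a number 34 percentage points higher from compound 3 to compound 4 (beyond the scatter), so the size of this change depends on how that carbon is drawn. Mirroring that single stereocentre gives a number 18 percentage points higher from compound 2 to compound 4 (beyond the scatter), which can be read as an effect of configuration alone: the fact that compounds 2 and 4 differ only in the configuration as drawn. Against the piperidin-4-yl side chain, the result is a number 7 percentage points higher from compound 1 to compound 4 (within the scatter).

Going by these compounds, whether configuration matters as much for a pyrrolidin-3-yl group or a longer chain at this position remains open. The compounds shown also do not explain why the two drawn forms give different numbers.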